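Swapping a methyl for a nitrile on the benzamide ring

The source may report more compounds than this note shows. Statements on the series, on what has been measured and on what is new or still open speak of the compounds shown alone.

Three amides of one shared pattern have been measured in an assay on membranes from brain for binding affinity to metabotropic glutamate receptor 5 (Rattus norvegicus); a higher number here means a weaker inhibitor, a lower number a stronger inhibitor. Compound 1 `Cc1csc(NC(=O)c2cccc(Cl)c2)n1` gives 5490 nM. Compound 2 `Cc1cccc(NC(=O)c2cccc3ccccc23)n1` gives 62800 nM. Compound 3 `Cc1cccc(C(=O)Nc2cccc(C)n2)c1` gives 1840 nM, the lowest of the three numbers: the step from compound 3 to compound 1 lies beyond the scatter, and the step from compound 3 to compound 2 lies well beyond it, so compound 3 is the strongest inhibitor of the measured set.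

Compound 4 `Cc1cccc(NC(=O)c2cccc(C#N)c2)n1` has not yet been measured. It differs from compound 3 in one place: cyano in place of methyl on an aromatic carbon, on an aromatic carbon of a six-membered aromatic ring of carbon only, meta to a large group. Within the data shown here, no pair of measured compounds shows this change, so the size of the step from compound 3 to compound 4 cannot be read from the data. Given that compound 3 already gives 1840 nM, the expectation is a modest shift toward a lower number, of a size near the edge of the scatter, rather than a large move in either direction.

For compound 4 the estimated value in this assay is 900 nM, within a range from 300 nM to 3000 nM, which amounts to an expected step of a 2.0-fold lower number from compound 3 to compound 4 (0.31 log units; beyond the scatter).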

Compound 4, half-maximal inhibitory concentration: 330 nM
Compound 4: middle estimate off by 2.7-fold (0.44 log units), on the high side, and the stated range covers the measured number.
By their numbers in this assay, from the lowest: compound 4; then compound 3; then compound 1; then compound 2.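

In this assay, putting cyano in place of methyl on an aromatic carbon, meta to a large group, gives a 5.6-fold lower number from compound 3 to compound 4 (0.75 log units; beyond the scatter). Among these compounds, this is the first step in the set between two compounds that differ in one place, so it gives the first direct reading of this position: the change adds one heavy atom and one hydrogen-bond acceptor, the move lies beyond the scatter, and compound 4 now has the lowest number of the four. Nothing measured here bears on why the number falls with this change.

As far as these compounds go, it remains open whether the drop belongs to the cyano group in particular or would also appear with another group on the same carbon, such as a methoxy group, an amine or a carboxylic acid. From the compounds shown here alone, it is also open whether cyano would give a step of similar size on the core of compound 1, where the rest of the molecule differs from that of compound 4.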